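The source may report more compounds than this note shows. Statements on the series, on what has been measured and on what is new or still open speak of the compounds shown alone.

Three compounds share one core, a sugar carrying a purine-like ring with a group hung from one aromatic carbon. Compound 1 `OC[C@H]1O[C@@H](n2cnc3c(OCc4ccccc4)ncnc32)[C@H](O)[C@@H]1O` carries a benzyloxy group there; in an assay on isolated protein for binding affinity to Equilibrative nucleoside transporter 1 (Homo sapiens) (on this read-out higher numbers stand for weaker inhibition and lower numbers for stronger inhibition), compound 1 gives 2090 nM. Compound 2 `Cc1cccc(CSc2ncnc3c2ncn3[C@@H]2O[C@H](CO)[C@@H](O)[C@H]2O)c1` carries a (3-methylbenzyl)sulfanyl group instead, and compound 2 gives 12000 nM, a step of a 5.7-fold higher number from compound 1 to compound 2 (0.76 log units; beyond the scatter). Compound 3 `OC[C@H]1O[C@@H](n2cnc3c(CSc4ccccc4I)ncnc32)[C@H](O)[C@@H]1O` carries a chain ending in a 2-iodophenyl ring on a sulfur; compound 3 gives 282 nM, which is the lowest of the three numbers, the steps being a 7.4-fold lower number from compound 1 to compound 3 (0.87 log units; beyond the scatter) and a 43-fold lower number from compound 2 to compound 3 (1.63 log units; beyond the scatter).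

Compound 4 `N#Cc1ccc(SCc2ncnc3c2ncn3[C@@H]2O[C@H](CO)[C@@H](O)[C@H]2O)cc1` keeps the chain and sulfur of compound 3 and changes only the ring on the sulfur: 4-cyanophenyl in place of 2-iodophenyl on a sulfur. Within the data shown here, none of the measured steps swaps one substituent on this ring for another; the steps from compound 1 and compound 2 each alter the linking atoms as well, so they show only that changes at this position move the number a great deal in either direction. With the iodine-bearing ring gone, a weaker result than compound 3 seems more likely than a stronger one. Compound 4 is therefore expected to give about 1500 nM in this assay, within roughly 300 nM to 7000 nM, that is a step of a 5.3-fold higher number from compound 3 to compound 4 (0.73 log units; beyond the scatter), which is only a rough guess.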

Compound 4, half-maximal inhibitory concentration: 81.3 nM
Estimate against measurement, compound 4: 18-fold (1.27 log units) above, outside the stated range (below it).
By their numbers in this assay, from the lowest: compound 4; then compound 3; then compound 1; then compound 2.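

This is the first pair shown that keeps the shared core, the chain and the sulfur unchanged and alters only the ring on the sulfur, so the effect of this swap can be read on its own. In this assay, putting 4-cyanophenyl in place of 2-iodophenyl on a sulfur gives a 3.5-fold lower number from compound 3 to compound 4 (0.54 log units; beyond the scatter), a real gain in inhibition that shows iodine on this ring is not required for a low number. However, 2-iodophenyl and 4-cyanophenyl differ both in the group carried on the ring and in where that group sits, and nothing measured here explains the drop in the number.

Going by these compounds, it remains open whether the gain belongs to the nitrile itself or to its place on the ring, and a single step cannot separate the two. Also open, on these data alone, is how the number would respond if an amine or a carboxylic acid stood on this ring in place of the nitrile, or if a longer chain joined the sulfur to the core.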